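Compound 3: Cyclopropyl in Place of Methyl

The source may report more compounds than this note shows. Statements on the series, on what has been measured and on what is new or still open speak of the compounds shown alone.

Measured so far:
compound 1, `CC(C)C(O)(c1cccc(-c2ccc(F)cc2)c1)c1c[nH]cn1`, gives 8.3 nM in an assay on microsomes from Testis (strain Sprague-Dawley) for inhibition of steroid 17-alpha-hydroxylase/17,20 lyase (Rattus norvegicus); a lower number here means a stronger inhibitor, a higher number a weaker inhibitor
compound 2, `CC(=O)Nc1cccc(-c2ccc(C(C)(O)c3c[nH]cn3)cc2)c1`, gives 62 nM in this assay

Of the two numbers in this assay, compound 2 stands at the higher one, with compound 1 at 8.3 nM, a lower number; the gap between them lies beyond the usual scatter. The two compounds differ in more than one place, so nothing about any single change can be read from that gap.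

Compound 3, `CC(=O)Nc1cccc(-c2ccc(C(O)(c3c[nH]cn3)C3CC3)cc2)c1`, differs from compound 2 in one place only: cyclopropyl in place of methyl on a saturated chain carbon bound to two aromatic carbons and an oxygen on a saturated carbon. Among the measured compounds shown here, no pair of measured compounds shows this change on its own, so the size of the step cannot be taken from the data and has to be expected. In this assay a modest move toward a lower number is expected, with the larger group entering where the methyl leaves, but of a size that may not clear the scatter. The step is expected to be a 2.1-fold lower number from compound 2 to compound 3 (0.32 log units; beyond the scatter). Compound 3 is accordingly estimated at 30 nM, in a range from 10 nM to 100 nM.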

Compound 3, half-maximal inhibitory concentration: 81 nM
For compound 3 the middle estimate is 2.7-fold (0.43 log units) below the measured one; the measured number falls inside the stated range.
By their numbers in this assay, from the lowest: compound 1; then compounds 2 and 3 (each within the scatter of the next).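

Among the compounds shown here, compound 3 gives the first reading of a single change at this position, the saturated chain carbon bound to two aromatic carbons and an oxygen on a saturated carbon: in this assay the swap of methyl for cyclopropyl amounts to a 1.3-fold higher number from compound 2 to compound 3 (0.12 log units; within the scatter) and no more. Two more heavy atoms and a three-membered ring on this carbon therefore leave compounds 2 and 3 level, so on this core the number does not respond measurably to this particular enlargement of the group. Nothing measured on these compounds speaks to why this step is so small.

On these data alone, what remains open is whether that flat response holds for much larger or differently built groups on the same carbon, such as a tert-butyl group, a phenyl ring or an amine-bearing chain. Compound 1, at 8.3 nM, carries yet another group on the equivalent carbon but differs from compounds 2 and 3 in more than one place, so how much of its gap to them belongs to this position cannot be read from the compounds shown.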